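This account rests on a few compounds, and the source may have more. Where it says the series, first, only, none or still open, it means among the compounds named here.

- compound 1 `CN(C)C(=O)/C=C/CNCCOc1ccc(Oc2c(-c3ccc(F)cc3)sc3cc(O)ccc23)cc1` gives 13800 nM
- compound 2 `O=C(/C=C/CN1CC(Oc2ccc(Oc3c(-c4ccc(F)cc4)sc4cc(O)ccc34)cc2)C1)N1CCCC1` gives 8450 nM

Both numbers come from a functional assay on MCF7 cells (Homo sapiens) for antiproliferative activity, read by CCK-8 assay, with a stated time of 48 h; on this read-out higher numbers stand for weaker inhibition and lower numbers for stronger inhibition. Compound 2, at 8450 nM, stands within the usual scatter of compound 1, so the two cannot be ranked, and both sit in the same broad range. The next compound, compound 3 `C=CC(=O)N1CC(Oc2ccc(Oc3c(-c4ccc(F)cc4)sc4cc(O)ccc34)cc2)C1`, changes compound 2 at one place: vinylcarbonyl in place of 3-((pyrrolidin-1-yl)carbonyl)prop-2-en-1-yl on an amine nitrogen in a ring. In words, vinylcarbonyl stands in place of 3-((pyrrolidin-1-yl)carbonyl)prop-2-en-1-yl on an amine nitrogen in a ring. Going by the values given here, no measured pair of compounds shows what a change at this place does, so the expectation is loose. The expected outcome is no shift beyond the scatter, with a slight lean towards stronger inhibition. The estimated change is a 1.2-fold lower number from compound 2 to compound 3 (0.08 log units; within the scatter). For compound 3 the expected value is 7000 nM, with an estimated range of 2500 nM to 20000 nM.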

Compound 3, half-maximal inhibitory concentration: 23500 nM
Estimate against measurement, compound 3: 3.4-fold (0.53 log units) below; the whole stated range lies below it.
By their numbers in this assay, from the lowest: compounds 2, 1 and 3 (each within the scatter of the next, the first and the last beyond it).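

On the amine nitrogen of the four-membered non-aromatic ring, the group matters: with vinylcarbonyl in place of 3-((pyrrolidin-1-yl)carbonyl)prop-2-en-1-yl, this assay gives a 2.8-fold higher number from compound 2 to compound 3 (0.44 log units; beyond the scatter), a modest loss of inhibition. The comparison with the open-chain compound gives a 1.7-fold higher number from compound 1 to compound 3 (0.23 log units; within the scatter), so 1-(vinylcarbonyl)azetidin-3-yl and 2-((3-(dimethylcarbamoyl)prop-2-en-1-yl)amino)ethyl on the oxygen on an aromatic ring cannot be ranked here. Nothing shown explains why the step from the larger group to vinylcarbonyl weakens inhibition.

That step removes the pyrrolidine ring and shortens the group at once, and the two changes cannot be separated from these compounds. An acetyl group on that nitrogen, or a longer chain ending in a piperidine ring, remains an open case.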